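A few compounds are considered here, and "the series" means these few. Any claim that something is new, unique, unknown or untested is made for them only; others in the source may bear on it.

The account concerns an ADME assay on microsomes from liver (Homo sapiens) for metabolic stability, read by LC-MS, using NADPH, tested at 5 uM (on this read-out lower numbers stand for a shorter-lived compound and higher numbers for a longer-lived compound), in which three compounds have been measured so far. Compound 1 `Cc1cccc(CSc2cc(Cl)c(C)cc2S(=O)(=O)/N=C(\N)n2nccc2-c2ccccc2)c1` gives 0.232 h in this assay. Compound 2 `Cc1cc(-c2ccccc2)n(/C(N)=N/S(=O)(=O)c2cc(C)c(Cl)cc2SCc2cccc(C(F)(F)F)c2)n1` gives 0.169 h. Compound 3 `Cc1cc(S(=O)(=O)/N=C(\N)n2nccc2-c2ccccc2)c(SCc2ccc(C(F)(F)F)cc2)cc1Cl` gives 0.176 h, the second highest of the three numbers; its nearest neighbour is compound 2 and its furthest is compound 1, and both of those gaps lie within the scatter of this kind of measurement, so none of the three can be set apart from the others.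

Compound 4 `Cc1cc(S(=O)(=O)/N=C(\N)n2nccc2-c2ccccc2)c(SCc2cccc(C(F)(F)F)c2)cc1Cl` has not yet been measured. It differs from compound 3 in one place: 3-(trifluoromethyl)phenyl in place of 4-(trifluoromethyl)phenyl on a saturated chain carbon bound to a sulfur. For the measured compounds named here, one measured step touches the same position, namely a 1.3-fold lower number from compound 1 to compound 3 (0.12 log units; within the scatter), which stayed within the scatter. Going by the values given here, compound 2 carries the same 3-(trifluoromethyl)benzyl group as compound 4 but differs from compound 3 elsewhere as well, so no single step connects it to compound 3; all that can be said is that the values of compound 2 and compound 3 sit within the scatter of one another. Nothing among these numbers points to a move beyond the scatter, and compound 4 is therefore expected to show a step of a 1.0-fold lower number from compound 3 to compound 4 (0.02 log units; within the scatter). Compound 4 is estimated at 0.17 h, with a range from 0.09 h to 0.34 h.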

Compound 4, half-life: 0.0863 h
Estimate against measurement, compound 4: 2.0-fold (0.29 log units) above; the measured number lies below the stated range.
By their numbers in this assay, from the lowest: compounds 4, 2, 3 and 1 (each within the scatter of the next, the first and the last beyond it).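

In this assay, the step of a 2.0-fold lower number from compound 3 to compound 4 (0.31 log units; beyond the scatter) lies beyond the scatter, though modestly, and shows that 3-(trifluoromethyl)phenyl and 4-(trifluoromethyl)phenyl on a saturated chain carbon bound to a sulfur can be told apart, which the earlier step of a 1.3-fold lower number from compound 1 to compound 3 (0.12 log units; within the scatter), within the scatter, gave no sign of. The step of a 2.7-fold lower number from compound 1 to compound 4 (0.43 log units; beyond the scatter), with trifluoromethyl in place of methyl on an aromatic carbon, is also modest and beyond the scatter, whereas the 4-(trifluoromethyl)phenyl of compound 3 had stayed within the scatter of compound 1, so at this position the outcome depends on where the trifluoromethyl sits as well as on its presence. By contrast, the step of a 2.0-fold lower number from compound 2 to compound 4 (0.29 log units; within the scatter), with hydrogen in place of methyl on an aromatic carbon, stays within the scatter, so that change cannot be separated from repeat variation here.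

The compounds shown leave open whether a methoxy group or a nitrile on the same phenyl would follow the 3-(trifluoromethyl)phenyl or the 4-(trifluoromethyl)phenyl result. Nothing available gives a reason for these differences.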